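Methyl on the aromatic nitrogen of compound 3

A few compounds are considered here, and "the series" means these few. Any claim that something is new, unique, unknown or untested is made for them only; others in the source may bear on it.

Values in a functional assay on P388 cells (Mus musculus) for inhibition (on this read-out lower numbers stand for stronger inhibition and higher numbers for weaker inhibition), each one a limit of the assay:
compound 1 `FC(F)(F)Oc1ccc(/C=C/c2ccc3ccccc3c2)cc1` gives > 5000 nM
compound 2 `O=S(=O)(c1ccccc1)n1ccc2cc(/C=C\c3ccc4ccccc4c3)ccc21` gives > 5000 nM
compound 3 `C(=C\c1ccc2[nH]ccc2c1)\c1ccc2ccccc2c1` gives > 5000 nM

Compound 3 stands only at a limit, > 5000 nM, and has no number of its own. The three compounds share that position (the limit of > 5000 nM in this assay, at which 3 of the 3 values shown sit) . Compound 4 `Cn1ccc2cc(/C=C\c3ccc4ccccc4c3)ccc21` differs from compound 3 by one change (methyl in place of hydrogen on an aromatic nitrogen) . Among the measured compounds shown here, the only measured step at that nitrogen (a step that the two limits leave unreadable from compound 2 to compound 3) has no readable size, so it offers no size or direction to carry over. No step beyond the scatter is therefore expected in this assay. The expected step is a step that the limit leaves unreadable from compound 3 to compound 4, and it remains tentative. Compound 4 is estimated at 6000 nM, with an expected range of 2000 nM to 20000 nM, and a report as a limit is likely.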

Compound 4, half-maximal inhibitory concentration: > 5000 nM
Compound 4 gave a limit, no number; the forecaster's own chance of this, stated with the estimate: 75%; the middle value does not contradict the limit.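

No step can be read from compound 2 to compound 4 or from compound 3 to compound 4, since in this assay all three compounds stand only at a limit: the limit of > 5000 nM in this assay, at which 4 of the 4 values shown sit.

The compounds shown leave open whether hydrogen, methyl and phenylsulfonyl on the aromatic nitrogen differ at all in this assay.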